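Piperazinyl for pyrrolidinyl on the glycinamide chain

This account rests on a few compounds, and the source may have more. Where it says the series, first, only, none or still open, it means among the compounds named here.

Compound 1 `CN(C)CC(=O)N1CCC(NS(=O)(=O)c2cc(S(=O)(=O)c3ccccc3)ccc2C(F)(F)F)CC1`: 280 nM
Compound 2 `O=C(CN1CCCC1)N1CCC(NS(=O)(=O)c2cc(S(=O)(=O)c3ccccc3)ccc2C(F)(F)F)CC1`: 190 nM

Both compounds share one core and differ only in the amine on a saturated chain carbon bound to a carbonyl carbon. In a functional assay on U2OS cells for antagonist activity at proto-oncogene Wnt-3 (Homo sapiens), read by a luciferase reporter, with a stated time of 18 h (on this read-out lower numbers stand for an effect already at smaller amounts and higher numbers for an effect only at larger amounts of compound), compound 2 gives the lowest of the two numbers, and its nearest neighbour is compound 1 with 280 nM; the step of a 1.5-fold lower number from compound 1 to compound 2 (0.17 log units; within the scatter) stays within the scatter. Compound 3 `O=C(CN1CCNCC1)N1CCC(NS(=O)(=O)c2cc(S(=O)(=O)c3ccccc3)ccc2C(F)(F)F)CC1` carries the change (piperazin-1-yl in place of pyrrolidin-1-yl on a saturated chain carbon bound to a carbonyl carbon). Among the measured compounds shown here, the one measured step that bears on it, a 1.5-fold lower number from compound 1 to compound 2 (0.17 log units; within the scatter), shows that exchanging the amine at this place left this assay essentially unchanged. Compound 3 is therefore expected to show no step beyond the scatter, a 1.3-fold higher number from compound 2 to compound 3 (0.12 log units; within the scatter), with a wide range for the added ring nitrogen. The estimate for compound 3 is 250 nM, between 90 nM and 700 nM.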

Compound 3, half-maximal effective concentration: 250 nM
For compound 3 middle estimate and measured number coincide at the digits printed, and the stated range covers the measured number.
By their numbers in this assay, from the lowest: compounds 2, 3 and 1 (each within the scatter of the next).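

Exchanging pyrrolidin-1-yl for piperazin-1-yl on a saturated chain carbon bound to a carbonyl carbon gives a 1.3-fold higher number from compound 2 to compound 3 (0.12 log units; within the scatter) and exchanging dimethylamino for it gives a 1.1-fold lower number from compound 1 to compound 3 (0.05 log units; within the scatter) in this assay. Beyond what the earlier pair showed, this place also accepts a six-membered ring with 2 hetero atoms and 1 hydrogen-bond donor, so the three amines shown, dimethylamino, pyrrolidin-1-yl and piperazin-1-yl, all lie within the scatter of one another in this assay. Nothing available explains why these exchanges leave the read-out so flat.

The compounds shown leave open whether a morpholine ring, a carboxylic acid or a longer chain at this place would also stay within the scatter. They also leave open whether any amine is needed here at all.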